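Replacing 4-methoxyphenyl with 3-fluorophenyl in compound 3

This account rests on a few compounds, and the source may have more. Where it says the series, first, only, none or still open, it means among the compounds named here.

Of the compounds shown here, three sharing one core have been measured in an ADME assay on BJ cells (Homo sapiens) for cytotoxicity, with a stated time of 72 h; a higher number here means that more compound is needed for the effect, a lower number that less compound is needed. Compound 1 `COc1ccc(/C=C/[C@@](C)(/C=C/c2ccc(O)c(C=O)c2)CCC=C(C)C)cc1`, which carries a formyl group, gives 9800 nM. Compound 2 `COc1ccc(/C=C/[C@@](C)(/C=C/c2ccc(O)c(/C=C/C#N)c2)CCC=C(C)C)cc1`, with 2-cyanoethenyl in that place, reads > 23700 nM, which is a limit of the assay and not a number. Compound 3 `COc1ccc(/C=C/[C@@](C)(/C=C/c2ccc(O)cc2)CCC=C(C)C)cc1`, with hydrogen there, reads > 36600 nM, which is also a limit. Compound 3 therefore has no exact value, and what separates the two limits is a step that the two limits leave unreadable from compound 2 to compound 3.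

Compound 4 `CC(C)=CCC[C@](C)(/C=C/c1ccc(O)cc1)/C=C/c1cccc(F)c1` has 3-fluorophenyl in place of 4-methoxyphenyl on a double-bonded chain carbon bound to a double-bonded chain carbon. Two measured steps give readable information, an at least 2.4-fold higher number from compound 1 to compound 2 (0.38 log units; beyond the scatter) and an at least 3.7-fold higher number from compound 1 to compound 3 (0.57 log units; beyond the scatter), and both lie beyond the scatter. For the measured compounds named here, both replace the formyl group, however, and no measured step changes 4-methoxyphenyl. Compound 4 has no formyl group, and the step of an at least 3.7-fold higher number from compound 1 to compound 3 (0.57 log units; beyond the scatter) shows a higher number in this assay once that group is gone, so no step beyond the scatter is expected and no direction can be favoured. The estimated step is a step that the limit leaves unreadable from compound 3 to compound 4. A reading that is again only a limit would be no surprise. For compound 4 the expected value is 40000 nM, with an estimated range of 15000 nM to 100000 nM.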

Compound 4, half-maximal effective concentration: > 36600 nM
Compound 4: a limit, no number; the forecaster's own chance of this, stated with the estimate: 65%; the middle value lies beyond the limit too.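

In this assay compound 4 reads > 36600 nM, which is a limit of the assay and not a number. For the compounds shown here, compound 3 stands at the same limit, so no step between compound 3 and compound 4 can be read. The compounds shown leave open whether 3-fluorophenyl in place of 4-methoxyphenyl changes the number at all.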